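Swapping the Piperazine End of a Side Chain

This account rests on a few compounds, and the source may have more. Where it says the series, first, only, none or still open, it means among the compounds named here.

In an ADME assay on L6 cells (Rattus norvegicus) for cytotoxicity, read by resazurin assay, with a stated time of 72 h (on this read-out lower numbers stand for stronger inhibition and higher numbers for weaker inhibition), compound 1 `CN(C)C12CC(c3ccccc3)C(CN(C(=O)CCN3CCCC3)C1)C(c1ccccc1)C2` gives 11700 nM, and compound 2 `CN1CCN(CCCN2CC3C(c4ccccc4)CC(N(C)C)(CC3c3ccccc3)C2)CC1` gives the lower number of the pair, 200 nM. Compound 3 `CCN(CC)CCCN1CC2C(c3ccccc3)CC(N(C)C)(CC2c2ccccc2)C1` differs from compound 2 by one change: diethylamino in place of 4-methylpiperazin-1-yl on a saturated chain carbon, three bonds along the chain from an amine nitrogen in a ring. The 3-(4-methylpiperazin-1-yl)propyl group thus becomes 3-(diethylamino)propyl. Among the measured compounds shown here, only one measured step bears on this, and it was large: a 59-fold lower number from compound 1 to compound 2 (1.77 log units; beyond the scatter). That step replaced the whole group on the amine nitrogen, whereas here the propyl chain stays, so a smaller shift towards weaker inhibition is expected. The estimated step is a 2.5-fold higher number from compound 2 to compound 3 (0.40 log units; beyond the scatter). For compound 3, the expected value is 500 nM, with an estimated range of 130 nM to 2500 nM.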

Compound 3, half-maximal inhibitory concentration: 3270 nM
The estimate for compound 3 lay 6.5-fold (0.82 log units) below the measured number, outside the stated range (above it).
By their numbers in this assay, from the lowest: compound 2; then compound 3; then compound 1.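

In this assay the end group alone matters greatly, even with the propyl chain kept (a 16-fold higher number from compound 2 to compound 3 (1.21 log units; beyond the scatter)). Replacing the whole group on the amine nitrogen in a ring gives a much smaller change when the new chain ends in diethylamino (a 3.6-fold lower number from compound 1 to compound 3 (0.55 log units; beyond the scatter)), so most of the large earlier step goes with the 4-methylpiperazin-1-yl end. No measurement here explains this difference. Still open, on these data alone, is whether the ring or its second nitrogen counts, which a piperidin-1-yl or morpholin-4-yl end on the same propyl chain would help to separate.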